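Notes on a fused aminonitrile series against the kinase

The compounds below may be only part of what the source reports. "The series", "measured", "known", "first", "only" and "open" are said of these compounds alone.

In an assay on isolated protein for binding affinity to Leucine-rich repeat serine/threonine-protein kinase 2 (Homo sapiens), read by TR-FRET and LanthaScreen, with a stated time of 2 h (a lower number here means a stronger inhibitor, a higher number a weaker inhibitor), compound 1 `CN(C)c1c(C#N)c2c(N)ncnc2n1C` gives 111 nM. Compound 3 `Cn1c(NCc2ccccc2F)c(C#N)c2c(N)ncnc21` gives 145 nM and compound 2 `C[C@@H]1CCCN1c1c(C#N)c2c(N)nc(Nc3cnn(C)c3)cc2n1C` gives 538 nM. Compound 1 shows the lowest of the three numbers; its gap to compound 3 lies within the scatter, while compound 2 lies beyond it. Compound 4 `Cn1c(N)c(C#N)c2c(N)ncnc21` has not been measured. It differs from compound 1 in one place: amino in place of dimethylamino on an aromatic carbon. Going by the values given here, no step between measured compounds is known, so the size of this change cannot be read from the data. Compound 3 gives 145 nM, within the scatter of compound 1, so a step of similar size is expected. The expected step for compound 4 is a 1.4-fold higher number from compound 1 to compound 4 (0.16 log units; within the scatter). In this assay compound 4 is estimated at 160 nM, between 55 nM and 470 nM.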

Compound 4, inhibition constant: 346 nM
The estimate for compound 4 lay 2.2-fold (0.33 log units) below the measured number; low and high end bracket the measured number.
By their numbers in this assay, from the lowest: compounds 1 and 3 (each within the scatter of the next); then compounds 4 and 2 (each within the scatter of the next).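

Amino in place of dimethylamino on this aromatic carbon gives in this assay a 3.1-fold higher number from compound 1 to compound 4 (0.49 log units; beyond the scatter) and is the first change in the series that can be read at a single place. The position therefore responds to its substituent, and the change tested here, which removes two carbons and adds a hydrogen-bond donor, moves compound 4 to the weaker side of compound 1.

From the compounds shown here alone, it remains open whether methylamino on this carbon would fall with compound 1 or with compound 4. Nothing available here explains the step.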